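Chloro in place of methoxy: what compound 4 may show

The compounds below may be only part of what the source reports. "The series", "measured", "known", "first", "only" and "open" are said of these compounds alone.

The measured compounds:
compound 1, `FC(F)(F)Oc1ccc(-c2cc(COc3ccccc3-c3nc4ccccc4s3)on2)cc1`, gives in a functional assay on MCF7 cells (Homo sapiens) for cytotoxicity, read by MTT assay, with a stated time of 24 h (on this read-out higher numbers stand for weaker inhibition and lower numbers for stronger inhibition), a value of 26600 nM;
compound 2, `Fc1ccccc1-c1cc(COc2ccccc2-c2nc3ccccc3s2)on1`, gives in this assay a value of 23900 nM;
compound 3, `COc1ccc(-c2cc(COc3ccccc3-c3nc4ccccc4s3)on2)cc1`, gives in this assay a value of 22100 nM.

Compound 3 holds the lowest of the three numbers, yet a 1.2-fold lower number from compound 1 to compound 3 (0.08 log units; within the scatter) and a 1.1-fold lower number from compound 2 to compound 3 (0.03 log units; within the scatter), so the three stand together. Compound 4, `Clc1ccc(-c2cc(COc3ccccc3-c3nc4ccccc4s3)on2)cc1`, differs from compound 3 by chloro in place of methoxy on an aromatic carbon. Among the measured compounds shown here, the steps that bear on it are the changes of the ring group at the same end of the core, a 1.1-fold lower number from compound 2 to compound 3 (0.03 log units; within the scatter) and a 1.1-fold lower number from compound 1 to compound 2 (0.05 log units; within the scatter), neither beyond the scatter. No step beyond the scatter is therefore expected, a 1.1-fold higher number from compound 3 to compound 4 (0.04 log units; within the scatter). Compound 4 is estimated at 24000 nM, within 12000 nM to 48000 nM.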

Compound 4, half-maximal inhibitory concentration: 23800 nM
For compound 4 the middle estimate is 1.0-fold (0.00 log units) above the measured one; the measured number falls inside the stated range.
By their numbers in this assay, from the lowest: compounds 3, 4, 2 and 1 (each within the scatter of the next).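

With chloro, a single chlorine atom with no hydrogen-bond acceptor, in this assay, the group para to a large group no longer carries an oxygen, yet the number stays within the scatter of methoxy (a 1.1-fold higher number from compound 3 to compound 4 (0.03 log units; within the scatter)) and trifluoromethoxy (a 1.1-fold lower number from compound 1 to compound 4 (0.05 log units; within the scatter)). The 4-chlorophenyl and 2-fluorophenyl compounds also stand together (a 1.0-fold lower number from compound 2 to compound 4 (0.00 log units; within the scatter)). No measurement at hand accounts for this result. Going by these compounds, whether an amine, a carboxylic acid or a longer chain at this position would give a step beyond the scatter remains open, as do changes elsewhere on the shared core.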